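The source may report more compounds than this note shows. Statements on the series, on what has been measured and on what is new or still open speak of the compounds shown alone.

Measured in a functional assay on Hep 3B2 cells (Homo sapiens) for inhibition, read by sulforhodamine B assay, with a stated time of 72 h; a higher number here means a weaker inhibitor, a lower number a stronger inhibitor:

Compound 1 `C[C@H](Nc1nc(N)nc(N)c1C#N)c1nn(-c2cccc(S(C)(=O)=O)c2)c2cc(F)ccc12`: 19700 nM
Compound 2 `C[C@H](Nc1ncnc2[nH]cnc12)c1nn(-c2cccnc2)c2ccc(F)cc12`: 40100 nM

Of these two compounds, compound 2 carries the higher number, 40100 nM, and so is the weaker inhibitor. Its gap to compound 1 lies beyond the usual scatter. Compound 3 `Cc1ccc2c(c1)c([C@H](C)Nc1ncnc3[nH]cnc13)nn2-c1cccnc1` keeps the core of compound 2 and has methyl in place of fluoro on an aromatic carbon. Among the measured compounds shown here, no measured pair shows this swap, so the data give no direct guide to its effect. The expectation therefore rests on compound 2 at 40100 nM, and no change beyond the scatter is expected in this assay. The expected step is small: a 1.1-fold lower number from compound 2 to compound 3 (0.06 log units; within the scatter). For compound 3 the estimated value is 35000 nM, with an expected range from 14000 nM to 75000 nM.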

Compound 3, half-maximal inhibitory concentration: > 40000 nM
Compound 3: no number, only a limit (the forecaster's own chance of this, stated with the estimate: 15%); at least 1.1-fold (0.05 log units) between middle value and limit.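

In this assay compound 3 gives > 40000 nM, which is a limit and not a number. Among the compounds shown here, no step from compound 2 to compound 3 can be read. The compounds shown leave open what methyl in place of fluoro on an aromatic carbon does in this assay.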